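Nitro in place of methoxy: expectation for compound 3

The compounds below may be only part of what the source reports. "The series", "measured", "known", "first", "only" and "open" are said of these compounds alone.

Measured so far:
- compound 1 (`C#CCOc1ccc(/C=C/C(=O)c2ccc(Br)cc2)cc1`): 22%
- compound 2 (`C#CCOc1ccc(/C=C/C(=O)c2ccc(OC)cc2)cc1`): 25%

For the measured compounds named here, in a functional assay on HepG2 cells (Homo sapiens) for inhibition, read by MTT assay, with a stated time of 48 h, tested at 10 uM (a lower number here means less inhibition of growth, a higher number more inhibition of growth at the concentration tested), compound 2 gives 25% and stands within the scatter of compound 1, the only other compound measured so far. The next analogue is compound 3 (`C#CCOc1ccc(/C=C/C(=O)c2ccc([N+](=O)[O-])cc2)cc1`), which carries nitro in place of methoxy on an aromatic carbon, para to a large group (nitro in place of methoxy on an aromatic carbon). Going by the values given here, one measured step bears on this change: a number 3 percentage points higher from compound 1 to compound 2 (within the scatter) with methoxy in place of bromo on an aromatic carbon. Among the compounds with values here, that small step is the only guide and no nitro compound has been measured, so no step beyond the scatter is expected, and the range stays wide. The expected step is a number 3 percentage points higher from compound 2 to compound 3 (within the scatter) and it remains an estimate. In this assay compound 3 is expected at 28% within an estimated range from 14% to 48% at this stage.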

Compound 3, percent growth inhibition at one concentration: 27%
For compound 3 the middle estimate is 1 percentage points above the measured one; the range from low to high includes it.
By their numbers in this assay, from the lowest: compounds 1, 2 and 3 (each within the scatter of the next).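

Replacing methoxy with nitro on the aromatic carbon para to a large group gives, in this assay, a number 2 percentage points higher from compound 2 to compound 3 (within the scatter), and replacing bromo with nitro at the same place gives a number 5 percentage points higher from compound 1 to compound 3 (within the scatter). With nitro added, this position has now carried three different groups, and no exchange among them has moved the read-out beyond the scatter at the single concentration tested. No available measurement offers an explanation for this flat result.

Still open, as far as these compounds go, is whether an amine, a carboxylic acid or a longer chain at this position would give a step beyond the scatter. Also open, from the compounds shown here alone, is whether the same flat picture would hold for changes elsewhere on the shared core, such as replacing the groups on its other aromatic ring.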